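Chloro for Methoxy on the Pendant Aryl Ring

A few compounds are considered here, and "the series" means these few. Any claim that something is new, unique, unknown or untested is made for them only; others in the source may bear on it.

Compound 3 `COc1ccc(C2=NN(C3=NC(=O)/C(=C4\C(=O)Nc5ccc(Cl)cc54)S3)C(c3ccc(OC)cc3)C2)cc1` gives 280 nM in a functional assay on cells (Leukemia cell, Homo sapiens) for cytotoxicity, read by sulforhodamine B assay, with a stated time of 48 h; on this read-out lower numbers stand for stronger inhibition of growth and higher numbers for weaker inhibition of growth. That places it level with compound 2 `COc1ccc(C2=NN(C3=NC(=O)/C(=C4\C(=O)Nc5ccc(Br)cc54)S3)C(c3ccc(OC)cc3)C2)cc1`, which gives 280 nM, and the two together stand at the highest of the three numbers, while compound 1 `O=C1N=C(N2N=C(c3ccccc3)CC2c2ccccc2O)S/C1=C1/C(=O)Nc2ccc(Br)cc21`, which gives 270 nM, lies within the scatter of both. Compound 3 is compound 2 with chloro in place of bromo, and that step reads no change at the digits printed from compound 2 to compound 3 (within the scatter). Compound 4 `COc1ccc(C2=NN(C3=NC(=O)/C(=C4\C(=O)Nc5ccc(Cl)cc54)S3)C(c3ccc(Cl)cc3)C2)cc1` is compound 3 with one further change: chloro in place of methoxy on an aromatic carbon. Going by the values given here, no measured step trades a methoxy for a chloro, so nothing among the three measured compounds bears on this change directly; the one step that does touch a ring substituent, bromo to chloro, moved nothing, and all three compounds sit in one narrow band. On that basis the step expected in this assay is no change at the digits printed from compound 3 to compound 4 (within the scatter), no larger than the scatter in either direction. Compound 4 is therefore estimated at 280 nM, with a range from 130 nM to 600 nM.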

Compound 4, concentration for 50% growth inhibition: 270 nM
Compound 4: middle estimate off by 1.0-fold (0.02 log units), on the high side; the measured number falls inside the stated range.
By their numbers in this assay, from the lowest: compounds 1, 4, 2 and 3 (each within the scatter of the next).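

In this assay, going by these compounds alone, the exchange of methoxy for chloro on this ring gives a 1.0-fold lower number from compound 3 to compound 4 (0.02 log units; within the scatter), the first reading at this place, since the earlier step changed a halogen elsewhere on the core. The 4-methoxyphenyl and 4-chlorophenyl forms therefore cannot be told apart on this read-out, and the oxygen of the methoxy is not needed at this place to hold the number in the band of the other compounds. No evidence is at hand to explain this flat reading.

As far as these compounds go, whether an amine or a carboxylic acid at this same place would stay in that band remains open. So does the part played by the methoxy that compound 4 retains on its other aryl ring.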